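Swapping a bromine for cyclopentyl on a shared thiophene core

A few compounds are considered here, and "the series" means these few. Any claim that something is new, unique, unknown or untested is made for them only; others in the source may bear on it.

Of the compounds shown here, three sharing one core have been measured in an ADME assay on MDCK cells (Canis lupus familiaris) for cytotoxicity, read by microscopy, with a stated time of 48 h; on this read-out lower numbers stand for higher toxicity in this test and higher numbers for lower toxicity in this test. Compound 1 `C[C@H]1[C@H](NCc2cc(-c3ccsc3)cs2)C[C@H]2C[C@@H]1C2(C)C` gives 25000 nM, and compound 2 `C=C(C)c1csc(CN[C@@H]2C[C@H]3C[C@@H]([C@H]2C)C3(C)C)c1` gives 25000 nM; the step of no change at the digits printed from compound 1 to compound 2 (within the scatter). Compound 3 `C[C@H]1[C@H](NCc2cc(Br)cs2)C[C@H]2C[C@@H]1C2(C)C` gives 6250 nM, the lowest of the three numbers, meaning it shows toxicity at a lower concentration than either neighbour. The two steps that lead to it, a 4.0-fold lower number from compound 1 to compound 3 (0.60 log units; beyond the scatter) and a 4.0-fold lower number from compound 2 to compound 3 (0.60 log units; beyond the scatter), both show the same modest shift when bromo takes the place of a larger carbon group.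

Compound 4 `C[C@H]1[C@H](NCc2cc(C3CCCC3)cs2)C[C@H]2C[C@@H]1C2(C)C` is not yet measured. Its change from compound 3 is cyclopentyl in place of bromo on an aromatic carbon. This reverses the direction of the two measured steps: a single bromine leaves and a larger carbon group enters. On that basis a modest rise in the number is expected, with a 4.0-fold higher number from compound 3 to compound 4 (0.60 log units; beyond the scatter) as the estimated step. Compound 4 is therefore expected to give about 25000 nM in this assay, with a likely range from 12500 nM to 50000 nM.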

Compound 4, minimum cytotoxic concentration: 1560 nM
Estimate against measurement, compound 4: 16-fold (1.20 log units) above, outside the stated range (below it).
By their numbers in this assay, from the lowest: compound 4; then compound 3; then compounds 1 and 2 (each within the scatter of the next).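

Carbon groups at this position do not all raise the number in this assay: putting cyclopentyl in place of bromo brings a 4.0-fold lower number from compound 3 to compound 4 (0.60 log units; beyond the scatter) and makes compound 4 the lowest of the four. The distance from the other two carbon groups is much larger, with a 16-fold lower number from compound 2 to compound 4 (1.20 log units; beyond the scatter) for the change from 1-methylethenyl and a 16-fold lower number from compound 1 to compound 4 (1.20 log units; beyond the scatter) for the change from thiophen-3-yl. Carrying a ring at this position therefore does not settle the number, since the aromatic thiophen-3-yl and the non-aromatic cyclopentyl lie far apart.

Nothing shown here explains why cyclopentyl lowers the number. From the compounds shown here alone, it also remains open whether cyclohexyl, an open chain such as pentyl, or a ring containing an amine, such as piperidinyl, would follow cyclopentyl or thiophen-3-yl.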